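The source may report more compounds than this note shows. Statements on the series, on what has been measured and on what is new or still open speak of the compounds shown alone.

Going by the values given here, compound 2 `COc1ccc(OC)c(/C=C/C(=O)N/N=C/c2ccc(Cl)cc2)c1` is the single compound with a number here: in a functional assay on BT-549 cells (Homo sapiens) for antiproliferative activity, read by sulforhodamine B assay, with a stated time of 48 h (on this read-out lower numbers stand for stronger inhibition of growth and higher numbers for weaker inhibition of growth), compound 2 gives 1170 nM. Compound 1 `COc1ccc(OC)c(/C=C/c2nnc(Nc3ccc(Cl)cc3)o2)c1` belongs to the same study, but in this assay compound 1 stands as "not determined" (no result reported), so nothing can be said about how it compares. Compound 3 `COc1ccc(OC)c(/C=C/C(=O)N/N=C/c2ccccc2)c1` differs from compound 2 by hydrogen in place of chloro on an aromatic carbon. Among the compounds with values here, no measured step of this kind is available, so the expectation rests on compound 2 alone. A modest weakening is expected, roughly a 1.6-fold higher number from compound 2 to compound 3 (0.21 log units; within the scatter), with no step beyond the scatter ruled out. Compound 3 is therefore estimated at 1900 nM, between 700 nM and 5500 nM.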

Compound 3, concentration for 50% growth inhibition: 4050 nM
Compound 3: the middle estimate sits 2.1-fold (0.33 log units) below what was measured; the measured number falls inside the stated range.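

Removing the chloro matters at this position: in this assay, going from 4-chlorophenyl to phenyl brings a 3.5-fold higher number from compound 2 to compound 3 (0.54 log units; beyond the scatter) and so weaker inhibition of growth. This single pair therefore shows that the para site of this ring is sensitive to what it carries, which compound 2 alone could not show. Nothing at hand explains why the chloro helps.

As far as these compounds go, whether fluoro, methoxy or an amine at the same place would match the chloro stays open. One step also cannot show whether this change would count equally on another core.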